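A trimethoxyphenyl group on the saturated ring carbon

The source may report more compounds than this note shows. Statements on the series, on what has been measured and on what is new or still open speak of the compounds shown alone.

Compound 2 `Cc1cc(O)c(C2=NN(c3ccc(S(N)(=O)=O)cc3)C(/C=C/c3ccccc3)C2)cc1Cl` in a functional assay on NCI-H460 cells (Homo sapiens) for antiproliferative activity, with a stated time of 48 h (a higher number here means a weaker inhibitor of growth, a lower number a stronger inhibitor of growth), gives 4030 nM. Compound 1 `Cc1cc(O)c(C2=NN(c3ccc(S(N)(=O)=O)cc3)C(c3ccccc3O)C2)cc1Cl` in this assay gives 2060 nM, and the step of a 2.0-fold higher number from compound 1 to compound 2 (0.29 log units; within the scatter) leaves the two compounds level. Compound 3 `COc1ccc(C2CC(c3cc(Cl)c(C)cc3O)=NN2c2ccc(S(N)(=O)=O)cc2)c(OC)c1OC` differs from compound 2 by 2,3,4-trimethoxyphenyl in place of 2-phenylethenyl on a saturated ring carbon. Within the data shown here, the only measured step at that same saturated ring carbon, from compound 1 to compound 2, stayed within the scatter, so no shift beyond the scatter is expected for compound 3. Compound 3 is therefore estimated at 3000 nM, between 900 nM and 10000 nM, which would mean a step of a 1.3-fold lower number from compound 2 to compound 3 (0.13 log units; within the scatter).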

Compound 3, concentration for 50% growth inhibition: 2120 nM
For compound 3 the middle estimate is 1.4-fold (0.15 log units) above the measured one; measured number inside the range.
By their numbers in this assay, from the lowest: compounds 1, 3 and 2 (each within the scatter of the next).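

In this assay, 2,3,4-trimethoxyphenyl on the saturated ring carbon gives a 1.9-fold lower number from compound 2 to compound 3 (0.28 log units; within the scatter) and a 1.0-fold higher number from compound 1 to compound 3 (0.01 log units; within the scatter), so all three groups at this position now stand level. Even with 12 heavy atoms and 3 hydrogen-bond acceptors entering in place of the 8 heavy atoms and no acceptors of 2-phenylethenyl, the number stays within the scatter. No evidence is available to explain this result.

From the compounds shown here alone, whether any group at this carbon can move the number beyond the scatter remains open. An amine or a carboxylic acid there would be an untested case in the compounds shown.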